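Swapping the Aryl Group on the Ring Nitrogen

This account rests on a few compounds, and the source may have more. Where it says the series, first, only, none or still open, it means among the compounds named here.

Measured compounds:
compound 1 `Fc1cccc(-c2nc(Nc3ccccc3)c3cc(F)ccc3n2)c1`: 49700 nM
compound 2 `COc1ccc(Nc2nc(-c3cccc(F)c3)nc3ccc(F)cc23)cc1`: 46800 nM
compound 3 `Fc1cccc(Nc2nc(-c3cccc(F)c3)nc3ccc(F)cc23)c1`: > 50000 nM

All three compounds were tested in a functional assay on COLO 205 cells (Homo sapiens) for cytotoxicity, read by MTT assay, with a stated time of 48 h; on this read-out lower numbers stand for stronger inhibition and higher numbers for weaker inhibition. Compound 1 gives 49700 nM and compound 2 gives 46800 nM. For compound 3 the assay reports only a limit, > 50000 nM, so no number is known for it. Compound 3 therefore stands at the limit of > 50000 nM in this assay, at which 1 of the 3 values shown sits.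

Compound 4 `Fc1cccc(-c2nc(Nc3ccc(Cl)cc3)c3cc(F)ccc3n2)c1` has not yet been measured. It differs from compound 3 by 4-chlorophenyl in place of 3-fluorophenyl on a nitrogen on an aromatic ring. Going by the values given here, three measured steps bear on this change. Between compound 1 and compound 2 the step was a 1.1-fold lower number from compound 1 to compound 2 (0.03 log units; within the scatter). Between compound 1 and compound 3 it was a number no lower from compound 1 to compound 3 (the limit leaves the size open). The closest comparison is the exchange of the group on the same nitrogen, where the step was an at least 1.0-fold higher number from compound 2 to compound 3 (0.02 log units; that floor lies within the scatter). None of these moves beyond the scatter, so another exchange of the group on that nitrogen is expected to leave the number roughly where it is, a step of a number no higher from compound 3 to compound 4 (the limit leaves the size open) being expected rather than any clear gain or loss. Compound 4 is therefore estimated at 50000 nM, with a range from 25000 nM to 100000 nM, and a fair chance that only a limit is reported.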

Compound 4, half-maximal inhibitory concentration: 32600 nM
Compound 4: middle estimate off by 1.5-fold (0.19 log units), on the high side; low and high end bracket the measured number.
By their numbers in this assay, from the lowest: compounds 4, 2 and 1 (each within the scatter of the next). At a limit, above all of these: compound 3.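

Compound 4 puts chloro in place of hydrogen or methoxy on an aromatic carbon of the ring on this nitrogen, and neither the step of a 1.5-fold lower number from compound 1 to compound 4 (0.18 log units; within the scatter) nor the step of a 1.4-fold lower number from compound 2 to compound 4 (0.16 log units; within the scatter) gets clear of what repeated measurements would give in this assay. For the exchange of 3-fluorophenyl for 4-chlorophenyl, the step reads an at least 1.5-fold lower number from compound 3 to compound 4 (0.18 log units; that floor lies within the scatter), so only a floor is known, and even that gives no sign of a real difference. From the compounds shown here alone, the true size stays open, since compound 3 is recorded only as a limit: the limit of > 50000 nM in this assay, at which 1 of the 4 values shown sits.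

So four different aryl groups on this nitrogen have been compared, and the steps that can be read in full show no change beyond the scatter, while the size of any step involving compound 3 remains unknown. Still open, going by these compounds, is whether a group of another kind on that nitrogen, such as a ring carrying an amine or a carboxylic acid, or a longer chain in place of the ring, would shift the number clearly in this cell assay.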